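Replacing naphthalen-2-yl in compound 2

This account rests on a few compounds, and the source may have more. Where it says the series, first, only, none or still open, it means among the compounds named here.

Going by the values given here, in a functional assay on HCT-116 cells (Homo sapiens) for cytotoxicity, with a stated time of 72 h (on this read-out lower numbers stand for stronger inhibition and higher numbers for weaker inhibition), compound 1 (`COc1ccc(/C=C(/c2ccc(C)cc2)c2cc(OC)c(OC)c(OC)c2)cc1O`) gives 3000 nM and compound 2 (`COc1ccc(/C=C(\c2cc(OC)c(OC)c(OC)c2)c2ccc3ccccc3c2)cc1O`) gives 8000 nM as the higher of the two numbers so far. The next change, to compound 3 (`COc1ccc(/C=C(/c2ccc(OC)c(F)c2)c2cc(OC)c(OC)c(OC)c2)cc1O`), has 3-fluoro-4-methoxyphenyl in place of naphthalen-2-yl on a double-bonded chain carbon bound to an aromatic carbon and a double-bonded chain carbon. Among the compounds with values here, only one measured step bears on this place. It is a 2.7-fold higher number from compound 1 to compound 2 (0.43 log units; beyond the scatter) on going from 4-methylphenyl to naphthalen-2-yl, a modest change beyond the scatter. Compound 3 leaves naphthalen-2-yl again, so the number is expected to fall back by a similar modest amount, given the rise shown in a 2.7-fold higher number from compound 1 to compound 2 (0.43 log units; beyond the scatter) as the sole guide. Within the data shown here, no measured compound tests a fluoro or methoxy group on this ring, so the range stays wide. Expected in this assay is a 3.2-fold lower number from compound 2 to compound 3 (0.51 log units; beyond the scatter) of modest size, toward stronger inhibition. In this assay compound 3 is estimated at 2500 nM with 500 nM to 9000 nM as the expected range.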

Compound 3, half-maximal inhibitory concentration: 8000 nM
Compound 3: middle estimate off by 3.2-fold (0.51 log units), on the low side; the range from low to high includes it.
By their numbers in this assay, from the lowest: compound 1; then compounds 2 and 3 (each within the scatter of the next).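

In this assay, 3-fluoro-4-methoxyphenyl in place of naphthalen-2-yl on the double-bonded chain carbon gives no change at the digits printed from compound 2 to compound 3 (within the scatter), so the two groups cannot be told apart at this position, although one has two six-membered aromatic rings and no hydrogen-bond acceptor while the other has one such ring and one acceptor. Going by these compounds alone, measured against 4-methylphenyl, the same replacement gives a 2.7-fold higher number from compound 1 to compound 3 (0.43 log units; beyond the scatter), matching the earlier step from that group to naphthalen-2-yl and leaving 4-methylphenyl as the only one of the three groups with the lower number in this assay. Nothing available explains why these two different groups match or why both stand apart from 4-methylphenyl.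

Still open, going by these compounds, is whether the fluoro or the methoxy part of the 3-fluoro-4-methoxyphenyl group matters for the step from compound 1, a question that plain phenyl, 3-fluorophenyl and 4-methoxyphenyl at this place would address. Also open, on these data alone, is whether an aminophenyl or a carboxyphenyl at this position would fall with compound 1 or with compounds 2 and 3.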